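Terminal aryl swap in a bile acid receptor binding series

A few compounds are considered here, and "the series" means these few. Any claim that something is new, unique, unknown or untested is made for them only; others in the source may bear on it.

Measured compounds, read out in an assay on isolated protein with Bile acid receptor (Homo sapiens) as the target; a lower number here means that less compound is needed, a higher number that more compound is needed for the effect:
Compound 1, `COC(=O)/C=C/c1cccc(N(Cc2ccc(/C=C/c3c(Cl)cccc3Cl)cc2)C(=O)C(C)C)c1`, gives 195 nM.
Compound 2, `COC(=O)/C=C/c1cccc(N(Cc2ccc(/C=C/c3ccc(F)cc3)cc2)C(=O)C(C)C)c1`, gives 120 nM.
Compound 3, `COC(=O)/C=C/c1cccc(N(Cc2ccc(-c3ccc(OC)cc3)cc2)C(=O)C(C)C)c1`, gives 97 nM.

Compound 3 shows the lowest of the three numbers, yet the gaps to its neighbours are small: a 2.0-fold lower number from compound 1 to compound 3 (0.30 log units; within the scatter) and a 1.2-fold lower number from compound 2 to compound 3 (0.09 log units; within the scatter), so no ranking among the three compounds is supported.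

Compound 4, `COC(=O)/C=C/c1cccc(N(Cc2ccc(-c3cccc(Cl)c3)cc2)C(=O)C(C)C)c1`, differs from compound 3 by 3-chlorophenyl in place of 4-methoxyphenyl on an aromatic carbon. For the measured compounds named here, no measured pair exchanges a methoxy-bearing phenyl for a chlorine-bearing phenyl directly on the shared core; the nearest precedents are the halogen and substituent swaps on the outer ring, a 1.6-fold lower number from compound 1 to compound 2 (0.21 log units; within the scatter), and the two exchanges that brought in the methoxyphenyl, a 2.0-fold lower number from compound 1 to compound 3 (0.30 log units; within the scatter) and a 1.2-fold lower number from compound 2 to compound 3 (0.09 log units; within the scatter), all within the scatter. Every variation of this outer ring seen so far has left this assay essentially unmoved, so for compound 4 a step of a 1.2-fold higher number from compound 3 to compound 4 (0.07 log units; within the scatter) is expected, that is no change beyond the scatter in either direction. Compound 4 is therefore estimated at 115 nM, with a likely range from 50 nM to 260 nM.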

Compound 4, half-maximal effective concentration: 77 nM
Compound 4: middle estimate off by 1.5-fold (0.17 log units), on the high side, and the stated range covers the measured number.
By their numbers in this assay, from the lowest: compounds 4, 3, 2 and 1 (each within the scatter of the next, the first and the last beyond it).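

Swapping 4-methoxyphenyl for 3-chlorophenyl on this aromatic carbon, para to a large group, gives a 1.3-fold lower number from compound 3 to compound 4 (0.10 log units; within the scatter) in this assay, so the outer ring tolerates a change in both substituent and substitution pattern, and an entering group with no hydrogen-bond acceptor leaves the number within the scatter. For the compounds shown here, replacing a whole styryl-type arm with this directly attached ring gives a 1.6-fold lower number from compound 2 to compound 4 (0.19 log units; within the scatter) for the 2-(4-fluorophenyl)ethenyl arm, but a 2.5-fold lower number from compound 1 to compound 4 (0.40 log units; beyond the scatter) for the 2-(2,6-dichlorophenyl)ethenyl arm, the only step so far that lies beyond the scatter, and a modest one. No independent data on these compounds bear on why this outer ring is so permissive.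

The compounds shown leave open whether the place of the chlorine matters, as 4-chlorophenyl would test against 3-chlorophenyl, and whether an unsubstituted phenyl behaves like the substituted rings. They also leave open how this position responds to an amine or a carboxylic acid on the outer ring, since only chlorine, fluorine and methoxy appear there.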